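This account rests on a few compounds, and the source may have more. Where it says the series, first, only, none or still open, it means among the compounds named here.

Compound 1 `COc1cc(O)c2c(c1)O[C@H](c1ccc(O)cc1)C/C2=N\Nc1ccc(Br)cn1`: 4300 nM
Compound 2 `COc1cc(O)c2c(c1)O[C@H](c1ccc(O)cc1)C/C2=N\NC(=O)c1ccc(N)cc1`: >= 11300 nM, a limit
Compound 3 `COc1cc(O)c2c(c1)O[C@H](c1ccc(O)cc1)C/C2=N\NC(=O)c1ccco1`: >= 11300 nM, a limit

All three compounds were tested in a functional assay on L5178Y cells (Mus musculus) for inhibition, read by MTT assay, with a stated time of 24 h (on this read-out lower numbers stand for stronger inhibition and higher numbers for weaker inhibition), and only compound 1 has an exact number. Compound 3 stands at the limit of >= 11300 nM in this assay, at which 2 of the 3 values shown sit.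

Compound 4 `COc1ccc([C@@H]2C/C(=N\NC(=O)c3ccco3)c3c(O)cc(OC)cc3O2)cc1` differs from compound 3 by methyl in place of hydrogen on an oxygen on an aromatic ring. Put simply, hydroxy becomes methoxy, turning 4-hydroxyphenyl into 4-methoxyphenyl.

Among the measured compounds shown here, no measured step touches this oxygen, so the evidence is only indirect. The measured steps all change the group on the amine nitrogen. Two of them lie beyond the scatter: an at least 2.6-fold higher number from compound 1 to compound 2 (0.41 log units; beyond the scatter) and an at least 2.6-fold higher number from compound 1 to compound 3 (0.41 log units; beyond the scatter). The third, a step that the two limits leave unreadable from compound 2 to compound 3, cannot be sized. None of them shows what a methyl on this oxygen does.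

The starting point is compound 3, whose >= 11300 nM is a limit. On these data alone, no step beyond the scatter is expected in this assay, and the direction remains open. The expected step is a step that the limit leaves unreadable from compound 3 to compound 4. The assay may well report only a limit again. For compound 4 the estimated value is 14000 nM, with an expected range from 6000 nM to 40000 nM.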

Compound 4, half-maximal inhibitory concentration: 2700 nM
The estimate for compound 4 lay 5.2-fold (0.71 log units) above the measured number; measured number below the stated range.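

The earlier compounds shown here varied only the group on the amine nitrogen, so they gave no reading on the oxygen of the 4-hydroxyphenyl group. This oxygen turns out to matter: in this assay, methyl in place of hydrogen on it gives an at least 4.1-fold lower number from compound 3 to compound 4 (0.62 log units; beyond the scatter), so here the change from hydroxy to methoxy goes with stronger inhibition. That step gives only a minimum size, since compound 3 sits at a limit rather than an exact number: the limit of >= 11300 nM in this assay, at which 2 of the 4 values shown sit.

On these data alone, all of this rests on a single pair carrying (furan-2-yl)carbonyl on the amine nitrogen, and whether the same methyl gives a similar step with 5-bromopyridin-2-yl or (4-aminophenyl)carbonyl there remains open. Also open, as far as these compounds go, is how a longer chain such as ethyl on this oxygen, or an amine in place of the hydroxy group, would read.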